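Shifting the methyl on the anilino ring of compound 3

The compounds below may be only part of what the source reports. "The series", "measured", "known", "first", "only" and "open" are said of these compounds alone.

Compound 3 `Cc1ccc(Nc2nc(SCc3cn(CC(=O)NC(=O)Nc4ccccn4)nn3)nc(-c3ccc(C(C)C)cc3)c2C#N)cc1` carries a 4-methylphenyl on the ring nitrogen of the shared core. In a functional assay on MCF7 cells (Homo sapiens) for inhibition, read by MTT assay, with a stated time of 72 h (a higher number here means a weaker inhibitor, a lower number a stronger inhibitor), compound 3 gives only a limit, > 64000 nM. Compound 2 `CC(C)c1ccc(-c2nc(SCc3cn(CC(=O)NC(=O)Nc4ccccn4)nn3)nc(Nc3ccccc3)c2C#N)cc1` gives the same kind of limit, > 64000 nM. Among the measured compounds shown here, compound 1 `CC(C)c1ccc(-c2nc(SCc3cn(CC(=O)NC(=O)Nc4ccccn4)nn3)nc(Nc3ccccc3Cl)c2C#N)cc1` is the only member with a number, 43700 nM. The step of an at least 1.4-fold higher number from compound 1 to compound 2 (0.16 log units; that floor lies within the scatter) and the step of an at least 1.4-fold higher number from compound 1 to compound 3 (0.16 log units; that floor lies within the scatter) each rest on that single number against a limit, and a step that the two limits leave unreadable from compound 2 to compound 3 cannot be read at all; the picture is shaped by the limit of > 64000 nM in this assay, at which 2 of the 3 values shown sit.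

Compound 4 `Cc1ccccc1Nc1nc(SCc2cn(CC(=O)NC(=O)Nc3ccccn3)nn2)nc(-c2ccc(C(C)C)cc2)c1C#N` differs from compound 3 by 2-methylphenyl in place of 4-methylphenyl on a nitrogen on an aromatic ring. Of the measured steps, only an at least 1.4-fold higher number from compound 1 to compound 3 (0.16 log units; that floor lies within the scatter) touches the same nitrogen, and it replaces a 2-chlorophenyl by a 4-methylphenyl; it is at most modest and sits at the floor of the scatter. Nothing measured separates a 2-methylphenyl from a 4-methylphenyl directly. The expectation for compound 4 in this assay is therefore no step beyond the scatter, expressed as an at least 1.0-fold lower number from compound 3 to compound 4 (0.02 log units; that floor lies within the scatter). Compound 4 is estimated at 60000 nM, within a range from 25000 nM to 150000 nM, with a fair chance that the assay again reports only a limit.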

Compound 4, half-maximal inhibitory concentration: > 64000 nM
Compound 4 gave a limit, no number; the forecaster's own chance of this, stated with the estimate: 55%; at least 1.0-fold (0.02 log units) between middle value and limit.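

In this assay compound 4 gives only a limit, > 64000 nM, so moving the methyl from the 4-methylphenyl to the 2-methylphenyl on this nitrogen produces no number, and the steps from compound 2 and from compound 3 to compound 4 cannot be read. Among the compounds shown here, the only step that can be read is an at least 1.4-fold higher number from compound 1 to compound 4 (0.16 log units; that floor lies within the scatter), with methyl in place of chloro on an aromatic carbon, and it does not separate the two groups. Compound 1 remains the only one of the four with a number, and what can be said about this position stops at this: the limit of > 64000 nM in this assay, at which 3 of the 4 values shown sit.

On these data alone, whether a 2-methylphenyl and a 4-methylphenyl on this nitrogen differ at all stays open, as does whether the number for compound 1 reflects anything particular to its chloro group. Also open, as far as these compounds go, is whether a methoxy or a fluoro group on the phenyl on this nitrogen would give a number in this assay.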